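Propyl Triazole with Chlorophenacyl Thioether: Expected Cytotoxicity

The source may report more compounds than this note shows. Statements on the series, on what has been measured and on what is new or still open speak of the compounds shown alone.

Compound 1 `Cc1nnc(SCC(=O)c2ccc(Cl)cc2)n1N1C(=O)c2ccccc2C1=O`: > 200000 nM
Compound 2 `C=CCSc1nnc(CCC)n1N1C(=O)c2ccccc2C1=O`: > 200000 nM
Compound 3 `CCCc1nnc(SCc2ccccc2)n1N1C(=O)c2ccccc2C1=O`: > 200000 nM

Of the compounds shown here, three have been tested in a functional assay on MKN-45 cells (Homo sapiens) for cytotoxicity, read by MTT assay, with a stated time of 48 h; on this read-out lower numbers stand for stronger inhibition and higher numbers for weaker inhibition. Compound 1 returns only the limit of the assay, > 200000 nM. Compound 2 likewise returns only a limit, > 200000 nM. Compound 3 also gives only a limit, > 200000 nM. The step that the two limits leave unreadable from compound 2 to compound 3 therefore cannot be read, and the limit of > 200000 nM in this assay, at which 3 of the 3 values shown sit, shows that no measured value stands apart from the others. Compound 3 thus stands at the limit, like the other two, and nothing among the three separates them.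

Compound 4 `CCCc1nnc(SCC(=O)c2ccc(Cl)cc2)n1N1C(=O)c2ccccc2C1=O` differs from compound 3 in one place: (4-chlorophenyl)carbonyl in place of phenyl on a saturated chain carbon bound to a sulfur. Among the measured compounds shown here, no measured step bears directly on this change. Compound 1 carries the same ((4-chlorophenyl)carbonyl)methyl group on its sulfur, and in this assay compound 1 gives > 200000 nM, a limit. Compound 3 carries the benzyl group in that position and also sits at the limit. For the measured compounds named here, nothing among the measured compounds points to a step beyond the scatter, so the expected step that the limit leaves unreadable from compound 3 to compound 4 is no change beyond the scatter. Compound 4 is estimated at 300000 nM, with a range from 100000 nM to 1000000 nM, and is most likely to be reported again only as a limit.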

Compound 4, half-maximal inhibitory concentration: > 200000 nM
Compound 4: no number, only a limit; the forecaster's own chance of this, stated with the estimate: 85%; the middle value lies beyond the limit too.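

In this assay compound 4 gives > 200000 nM as a limit and not a number. No new step can be read from it: the steps from compound 1, compound 2 and compound 3 to compound 4 all stay unreadable. The compounds shown leave open which change to the shared core, if any, would bring a readable value in this assay at all.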